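Open-chain amide series: phenylpiperazine in place of dimethylamino

The compounds below may be only part of what the source reports. "The series", "measured", "known", "first", "only" and "open" are said of these compounds alone.

Measured so far:
- compound 1, `NC(C(=O)NCC(=O)Nc1ccc(Cl)cc1C(=O)c1ccccc1)c1ccccc1`: 28 mg/kg
- compound 2, `CN(C)CC(=O)NCC(=O)N(C)c1ccc(Cl)cc1C(=O)c1ccccc1Cl`: 2.6 mg/kg
- compound 3, `NCC(=O)NCC(=O)Nc1ccc([N+](=O)[O-])cc1C(=O)c1ccccc1`: 4.82 mg/kg

All three values come from a functional assay on the whole organism for antagonist activity, with Mus musculus as the target; on this read-out higher numbers stand for an effect only at larger amounts of compound and lower numbers for an effect already at smaller amounts. Compound 2 gives 2.6 mg/kg in this assay, the lowest of the three numbers. The gap to compound 3 is within the usual scatter, so no order between compound 2 and compound 3 can be read from these figures. Compound 1 lies beyond the scatter from compound 2, and this is the only gap in the set that is clearly more than noise.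

Compound 4, `CN(C(=O)CNC(=O)CN1CCN(c2ccccc2)CC1)c1ccc(Cl)cc1C(=O)c1ccccc1Cl`, has not been measured in this assay. It differs from compound 2 in one place: 4-phenylpiperazin-1-yl in place of dimethylamino on a saturated chain carbon bound to a carbonyl carbon. Within the data shown here, no pair of measured compounds in this set differs only at this position, so nothing among the measured values speaks directly to this change.

In the absence of such a step, compound 4 is expected to sit close to compound 2, with a modest shift toward a higher number as the most likely outcome, a 1.9-fold higher number from compound 2 to compound 4 (0.28 log units; within the scatter). The estimate for compound 4 in this assay is 5 mg/kg, with a range from 1.3 mg/kg to 20 mg/kg.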

Compound 4, dose for half-maximal effect: 75 mg/kg
Compound 4: the middle estimate sits 15-fold (1.18 log units) below what was measured; the whole stated range lies below it.
By their numbers in this assay, from the lowest: compounds 2 and 3 (each within the scatter of the next); then compound 1; then compound 4.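

In this assay, 4-phenylpiperazin-1-yl in place of dimethylamino on a saturated chain carbon bound to a carbonyl carbon gives a 29-fold higher number from compound 2 to compound 4 (1.46 log units; beyond the scatter). Among these compounds, this is the first step in the set that isolates a single place, and it shows that the read-out is strongly sensitive to the group at this position, so the low number of compound 2 does not carry over to this replacement. The entering group differs from dimethylamino in having 12 heavy atoms rather than 3 and in carrying both a non-aromatic and an aromatic ring, but this single step cannot separate these features, and no measurement at hand offers an explanation for the shift.

Still open, going by these compounds, is which part of the new group matters: 4-methylpiperazin-1-yl would test the phenyl ring, while piperidin-1-yl or morpholin-4-yl on the same carbon would test the ring without it. Also open, on these data alone, is whether a longer chain between the carbonyl and the 4-phenylpiperazin-1-yl group changes the outcome of this replacement.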